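Swapping hydroxy for chloro on an alkyne-bearing quinoline-free sulfide core

A few compounds are considered here, and "the series" means these few. Any claim that something is new, unique, unknown or untested is made for them only; others in the source may bear on it.

Measured so far:
compound 1 `OCC#CCSc1cnc2ccccc2c1SCC#CCCl`: 5.1 ug/mL
compound 2 `CCOC(=O)OCC#CCSc1c(SC)cnc2ccccc12`: 34.7 ug/mL
compound 3 `CSc1cnc2ccccc2c1SCC#CCO`: 3.1 ug/mL

In a functional assay on P388 cells (Mus musculus) for antiproliferative activity, with a stated time of 72 h (a lower number here means a stronger inhibitor, a higher number a weaker inhibitor), compound 3 gives the lowest number of the three, though compound 1 sits within the scatter of it, and only compound 2 stands clearly apart, as the step of an 11-fold lower number from compound 2 to compound 3 (1.05 log units; beyond the scatter) shows. Compound 4 `CSc1cnc2ccccc2c1SCC#CCCl` differs from compound 3 by chloro in place of hydroxy on a saturated chain carbon bound to a triple-bonded carbon. Within the data shown here, no measured step covers this exchange; the one known step concerns an ethoxycarbonyl on the oxygen, not its removal. Compound 1, which carries a 4-chlorobut-2-yn-1-yl chain, shows a value close to that of compound 3. A small step, a 1.1-fold higher number from compound 3 to compound 4 (0.05 log units; within the scatter), within the scatter is therefore expected, and compound 4 is estimated at 3.5 ug/mL (range 1.5 ug/mL to 9 ug/mL).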

Compound 4, concentration for 50% inhibition: 2.7 ug/mL
Compound 4: the middle estimate sits 1.3-fold (0.11 log units) above what was measured; low and high end bracket the measured number.
By their numbers in this assay, from the lowest: compounds 4, 3 and 1 (each within the scatter of the next); then compound 2.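

In this assay the exchange of hydroxy for chloro gives a 1.1-fold lower number from compound 3 to compound 4 (0.06 log units; within the scatter) and so, on this saturated chain carbon bound to a triple-bonded carbon, the two groups cannot be told apart. Chloro in place of (ethoxycarbonyl)oxy at the same carbon is a different matter, with a 13-fold lower number from compound 2 to compound 4 (1.11 log units; beyond the scatter) as a large step. Hydrogen in place of 3-hydroxyprop-1-yn-1-yl on a saturated chain carbon bound to a sulfur gives a 1.9-fold lower number from compound 1 to compound 4 (0.28 log units; within the scatter) and thus no clear change either.

Nothing at hand explains these steps. Going by these compounds, whether an amine or a carboxylic acid on this carbon would behave like hydroxy and chloro stays open.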